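Adding chloro to compound 2: working notes

This account rests on a few compounds, and the source may have more. Where it says the series, first, only, none or still open, it means among the compounds named here.

compound 1 `N#Cc1ccc(-c2nc3ccccn3c2Sc2ccccc2)cc1`: 17800 nM
compound 2 `c1ccc(Sc2c(-c3cccs3)nc3ccccn23)cc1`: 69200 nM

Both values come from a functional assay on MDA-MB-231 cells (Homo sapiens) for inhibition, read by MTT assay, with a stated time of 48 h; on this read-out higher numbers stand for weaker inhibition and lower numbers for stronger inhibition. Among the compounds with values here, of the two numbers, compound 2 holds the higher at 69200 nM, and its only neighbour is compound 1, with a gap beyond the scatter. The next member, compound 3 `Clc1ccc(Sc2c(-c3cccs3)nc3ccccn23)cc1`, keeps the thiophen-2-yl group of compound 2 and has chloro in place of hydrogen on an aromatic carbon, turning phenyl to 4-chlorophenyl: chloro in place of hydrogen on an aromatic carbon. The series offers a single measured step, a 3.9-fold higher number from compound 1 to compound 2 (0.59 log units; beyond the scatter), which is modest. It swaps 4-cyanophenyl for thiophen-2-yl at another place, so it sets only a rough scale. Within the data shown here, no measured step touches the phenyl group that changes here. In this assay a modest step at most is therefore expected. With compound 2 at 69200 nM, the higher of the two numbers, a small move towards a lower number is the expectation, though none beyond the scatter remains possible. The expected move is a 1.5-fold lower number from compound 2 to compound 3 (0.19 log units; within the scatter). For compound 3 the estimated value is 45000 nM, with an expected range of 18000 nM to 110000 nM.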

Compound 3, half-maximal inhibitory concentration: 73100 nM
Estimate against measurement, compound 3: 1.6-fold (0.21 log units) below; the measured number falls inside the stated range.
By their numbers in this assay, from the lowest: compound 1; then compounds 2 and 3 (each within the scatter of the next).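

Within the data shown here, on the phenyl group of compound 2, chloro in place of hydrogen, on an aromatic carbon para to a large group, gives a 1.1-fold higher number from compound 2 to compound 3 (0.02 log units; within the scatter) in this assay, the first reading at this position. Among these compounds, compounds 2 and 3 therefore cannot be told apart here, so this single chlorine atom leaves the read-out within the scatter, whereas the only earlier step, at the other place on the core, lay beyond it. Nothing measured on these compounds offers an explanation for this result.

From the compounds shown here alone, a single substituent at one place on this ring says little about the position as a whole, and it remains open whether an amine, a carboxylic acid or a methoxy group there would also stay within the scatter of compound 2. Going by these compounds, it is equally open whether chloro at this place would behave the same way on compound 1, which carries 4-cyanophenyl instead of thiophen-2-yl and has the lower number of the pair that differ at that place.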